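The source may report more compounds than this note shows. Statements on the series, on what has been measured and on what is new or still open speak of the compounds shown alone.

In an ADME assay for permeability, using PAMPA, with a stated time of 4 h, at pH 7.4 (a higher number here means that the compound crosses the layer faster, a lower number that the compound crosses the layer more slowly), compound 3 `NC(=O)NC/C=C/CN(C[C@H]1Cc2ncccc2CN1)[C@H]1CCCc2cccnc21` gives 2 nm/s. That leaves compound 3 level with compound 2 `NCCCCN(C[C@H]1Cc2nccnc2CN1)[C@H]1CCCc2cccnc21`, which gives 2 nm/s in this assay; together they hold the lowest of the three numbers. Compound 1 `NCCCCN(C[C@H]1Cc2cccnc2CN1)[C@H]1CCCc2cccnc21` gives 6 nm/s in this assay, a gap from compound 3 that lies beyond the usual scatter.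

Compound 4 `c1cnc2c(c1)CN[C@@H](CN(CCCC1CCNCC1)[C@H]1CCCc3cccnc31)C2` is the next compound, built from compound 3 by one change: a group of 8 heavy atoms (7 carbon, 1 nitrogen; one six-membered non-aromatic ring with 1 hetero atom) in place of a group of 7 heavy atoms (4 carbon, 2 nitrogen, 1 oxygen; no ring), on a saturated chain carbon bound to an amine nitrogen. Among the measured compounds shown here, no measured pair here shows a step of this kind, so its size can only be guessed from the spread of the three numbers. A modest rise is expected, a 2.0-fold higher number from compound 3 to compound 4 (0.30 log units; within the scatter), possibly not clearing the scatter. Compound 4 is therefore estimated at 4 nm/s in this assay, with a range from 1.5 nm/s to 10 nm/s.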

Compound 4, apparent permeability: 24 nm/s
For compound 4 the middle estimate is 6.0-fold (0.78 log units) below the measured one; measured number above the stated range.
By their numbers in this assay, from the lowest: compounds 2 and 3 (each within the scatter of the next); then compound 1; then compound 4.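

In this assay, placing 2-(piperidin-4-yl)ethyl in the old chain's place, on a saturated chain carbon bound to an amine nitrogen, gives a 12-fold higher number from compound 3 to compound 4 (1.08 log units; beyond the scatter), a large step beyond the scatter. Among the compounds shown here, this shows that a change at this position can move the read-out strongly, which the earlier compounds, none a single change from another, could not show. Nothing measured here explains the step.

As far as these compounds go, the change swaps the ring, double bonds and hydrogen-bond donors together, so which of these matters stays open. A morpholine ring in place of the piperidine ring would test only part of this change.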